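Compound 4: does trifluoromethoxy lift compound 3 off the limit?

A few compounds are considered here, and "the series" means these few. Any claim that something is new, unique, unknown or untested is made for them only; others in the source may bear on it.

- compound 1 `O=C1Nc2c(C(F)(F)F)cccc2C1(c1ccc(O)cc1)N1CCCCC1` gives > 1000000 nM as a limit
- compound 2 `CC1CN(C2(c3ccc(O)cc3)C(=O)Nc3c(C(F)(F)F)cccc32)CCC1(F)F` gives 70 nM as a number
- compound 3 `O=C1Nc2c(C(F)(F)F)cccc2C1(c1ccc(O)cc1)N1CCC(O)CC1` gives > 1000000 nM as a limit

All three values come from a functional assay on MCF7 cells (Homo sapiens) for inhibition, read by resazurin assay, with a stated time of 24 h (a higher number here means a weaker inhibitor, a lower number a stronger inhibitor), and only one of them is a number. Compound 3 stands at > 1000000 nM which is a limit. This is the limit of > 1000000 nM in this assay, at which 2 of the 3 values shown sit, and compound 3 shares that place with compound 1.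

Compound 4 `O=C1Nc2c(C(F)(F)F)cccc2C1(c1ccc(O)cc1)N1CCC(OC(F)(F)F)CC1` has not been measured. Its difference from compound 3 is trifluoromethyl in place of hydrogen on an oxygen on a saturated carbon and in words the hydroxy becomes trifluoromethoxy.

Going by the values given here, no measured step makes this exact change, but two bear on it. One is an at least 14000-fold lower number from compound 1 to compound 2 (4.15 log units; beyond the scatter) and the other is an at least 14000-fold higher number from compound 2 to compound 3 (4.15 log units; beyond the scatter) and both swap only the group on a saturated ring carbon. A third is a step that the two limits leave unreadable from compound 1 to compound 3 and gives no size. Among the measured compounds only compound 2 carries fluorine, and compound 2 gives 70 nM in this assay as its value. This single case is thin support, so a large fall in the number is expected, with a real chance of staying at the limit. The expected step is an at least 500-fold lower number from compound 3 to compound 4 (2.69 log units; beyond the scatter) and it is uncertain. For compound 4 the estimate is 2000 nM with an expected range from 50 nM to 500000 nM in this measurement.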

Compound 4, half-maximal inhibitory concentration: 135 nM
For compound 4 the middle estimate is 15-fold (1.17 log units) above the measured one; the measured number falls inside the stated range.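

In this assay, going by these compounds alone, the change from hydroxy to trifluoromethoxy gives an at least 7400-fold lower number from compound 3 to compound 4 (3.86 log units; beyond the scatter), which makes this the only readable step at this oxygen and shows that the change can carry a compound off the limit. Measured against hydrogen on the same saturated ring carbon, trifluoromethoxy gives an at least 7400-fold lower number from compound 1 to compound 4 (3.86 log units; beyond the scatter), whereas the step from hydrogen to hydroxy on that carbon, with a limit at each end, cannot be read. Compound 1 and compound 3, the two compounds without fluorine on the six-membered non-aromatic ring, remain at a limit, so a fluorinated group on that ring now comes with a number in both compound 2 and compound 4, and none of the compounds shown goes against this: the limit of > 1000000 nM in this assay, at which 2 of the 4 values shown sit.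

What a methoxy group would give at this oxygen remains open, so the compounds shown do not separate the capping of the oxygen from the presence of the fluorine atoms. Also open, as far as these compounds go, is how an amine or a carboxylic acid on the same saturated ring carbon would read.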